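Acidity in a sulfone series: the ring-carbon tetrazolylsulfanyl group

A few compounds are considered here, and "the series" means these few. Any claim that something is new, unique, unknown or untested is made for them only; others in the source may bear on it.

Measured so far:
compound 1 `CO[C@H]1C(=O)N2C(C(=O)c3ccccc3)=C(C)C(Sc3nnnn3C)S(=O)(=O)[C@H]12`, a physicochemical assay for acid dissociation, 4.8
compound 2 `CO[C@H]1C(=O)N2C(C(=O)C(C)(C)C)=C(CSc3nnnn3C)CS(=O)(=O)[C@H]12`, this assay 11.6
compound 3 `CO[C@H]1C(=O)N2C(C(=O)C(C)(C)C)=C(CSc3nnnn3C)C(Sc3nnnn3C)S(=O)(=O)[C@H]12`, this assay 6

Compound 1 gives the lowest of the three numbers; compound 3 lies nearer to it, compound 2 furthest. The difference between the core of compound 1 and the core of compound 3 is not broken down here.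

Within the measured set one change is counted: hydrogen in place of (1-methyl-1H-tetrazol-5-yl)sulfanyl on a saturated ring carbon. It made a step of a number 5.60 log units higher from compound 3 to compound 2 (beyond the scatter).

Compound 4 `CO[C@H]1C(=O)N2C(C(=O)c3ccccc3)=C(C)CS(=O)(=O)[C@H]12` is not yet measured. It comes from compound 1 by the same kind of change, (hydrogen in place of (1-methyl-1H-tetrazol-5-yl)sulfanyl on a saturated ring carbon). The surroundings differ: in compound 1 the place is next to the ring atom that bears a methyl group and two ring bonds from the ring atom that bears a benzoyl group, whereas in compound 3 it is next to the ring atom that bears a ((1-methyl-1H-tetrazol-5-yl)sulfanyl)methyl group and two ring bonds from the ring atom that bears a (tert-butyl)carbonyl group.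

The step from compound 1 to compound 4 is expected to be a number 5.60 log units higher from compound 1 to compound 4 (beyond the scatter), resting on the step of a number 5.60 log units higher from compound 3 to compound 2 (beyond the scatter) seen once. Compound 4 is therefore estimated at 10.4 in this assay, plausibly between 9.4 and 11.6.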

Compound 4, acid dissociation constant: 9.6
The estimate for compound 4 lay 0.80 log units above the measured number; low and high end bracket the measured number.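

In this assay, hydrogen in place of (1-methyl-1H-tetrazol-5-yl)sulfanyl on a saturated ring carbon gives a number 4.80 log units higher from compound 1 to compound 4 (beyond the scatter), in the same direction as a number 5.60 log units higher from compound 3 to compound 2 (beyond the scatter), so the change carries across these two cores as a large rise in the number. The two cores differ in more than one place, so this pair does not show whether the benzoyl or methyl group of compound 1, or the (tert-butyl)carbonyl or ((1-methyl-1H-tetrazol-5-yl)sulfanyl)methyl group of compound 3, bears on the size of the step. No measurement available here explains the step.

The compounds shown leave open what an amine or a carboxylic acid on that saturated ring carbon would give. From the compounds shown here alone, whether the step holds with a longer chain in place of the methyl group also remains open.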